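The source may hold more compounds than are shown below. What is called first, only, known or untested is meant among the compounds shown, and "the series" means these compounds.

Measured compounds:
compound 1, `Cc1ccc(-c2ccnc(C(=O)Nc3ccc(Oc4ccnc5[nH]ccc45)cc3)n2)cc1`, 6410 nM
compound 2, `O=C(Nc1ccc(Oc2ccnc3[nH]ccc23)cc1)c1nccc(-c2ccc(Cl)cc2)n1`, "not active" (no number reported)
compound 3, `O=C(Nc1ccc(Oc2ccnc3[nH]ccc23)cc1)c1cc(-c2ccc(Cl)cc2)ncn1`, 7770 nM

In a functional assay on MCF7 cells (Homo sapiens) for cytotoxicity, read by MTT assay, with a stated time of 72 h (a lower number here means a stronger inhibitor, a higher number a weaker inhibitor), compound 1 gives 6410 nM. Compound 2 is reported in this assay as "not active" (no number reported), with no number attached. Compound 3 gives 7770 nM in this assay; its nearest neighbour on the numbers is compound 1, and the gap between the two lies within the usual scatter, so neither can be set above the other. Compound 2 stands apart, without a number, and cannot be placed against either.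

Compound 4, `O=C(Nc1ccc(Oc2ccnc3[nH]ccc23)cc1)c1cc(-c2ccc(Br)cc2)ncn1`, has not yet been measured. It differs from compound 3 in one place: bromo in place of chloro on an aromatic carbon. Among the compounds with values here, no pair of measured compounds shows this exchange, so there is no measured step to lean on. An exchange of one heavy atom for another at the same place is a small one, and here no step beyond the scatter is expected in either direction. The step from compound 3 to compound 4 is therefore expected to be a 1.0-fold lower number from compound 3 to compound 4 (0.02 log units; within the scatter). Compound 4 is accordingly estimated at 7500 nM in this assay, with an expected range from 3000 nM to 19000 nM.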

Compound 4, half-maximal inhibitory concentration: 3840 nM
For compound 4 the middle estimate is 2.0-fold (0.29 log units) above the measured one; the range from low to high includes it.
By their numbers in this assay, from the lowest: compounds 4, 1 and 3 (each within the scatter of the next, the first and the last beyond it).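

In this assay, bromo in place of chloro on an aromatic carbon, para to a large group, gives a 2.0-fold lower number from compound 3 to compound 4 (0.31 log units; beyond the scatter). Within the data shown here, this is the first step that can be read between two measured compounds differing in one place, and it shows that the number at this position can move with the exchange of one heavy atom, while no ring, hydrogen-bond donor, hydrogen-bond acceptor or net charge enters or leaves. The step is modest and rests on a single pair, and nothing measured here accounts for the lower number with bromo.

The compounds shown leave open how the same position answers to fluoro or iodo, and so whether this step continues along the halogens or belongs to bromo alone, and what a methoxy group, an amine or a carboxylic acid would do there in this assay. They also leave open whether the same exchange would carry over to the core of compound 2, whose entry has no number.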